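A few compounds are considered here, and "the series" means these few. Any claim that something is new, unique, unknown or untested is made for them only; others in the source may bear on it.

Measured compounds:
- compound 1, `CCCS(=O)(=O)Nc1ccc(F)c(C(=O)c2n[nH]c3ncc(-c4ccc(OC)cc4)cc23)c1F`, in an assay for binding affinity to dual specificity mitogen-activated protein kinase kinase 4 (Homo sapiens), read by KINOMEscan, tested at 100 nM (a higher number here means a weaker effect of the compound at the concentration tested, a lower number a stronger effect), gives 4.2%
- compound 2, `CCCS(=O)(=O)Nc1ccc(F)c(C(=O)c2n[nH]c3ncc(-c4ccc(C(C)C)cc4)cc23)c1F`, gives 17%
- compound 3, `CCCS(=O)(=O)Nc1ccc(F)c(C(=O)c2n[nH]c3ncc(-c4ccc(C(F)(F)F)cc4)cc23)c1F`, gives 29%

All three share one core and differ only in the group on an aromatic carbon of the outer six-membered ring of carbon only. Compound 3 stands at the top of these three numbers, meaning the weakest effect seen so far; the steps that lead up to it are a number 12 percentage points higher from compound 2 to compound 3 (beyond the scatter) and a number 24.8 percentage points higher from compound 1 to compound 3 (beyond the scatter), both beyond the scatter.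

Compound 4, `CCCS(=O)(=O)Nc1ccc(F)c(C(=O)c2n[nH]c3ncc(-c4ccc(S(=O)(=O)NC(C)=O)cc4)cc23)c1F`, is not yet measured. Its change from compound 3 is acetylsulfamoyl in place of trifluoromethyl on an aromatic carbon. The three measured steps all alter the same position, and each was modest: a number 12.8 percentage points higher from compound 1 to compound 2 (beyond the scatter), a number 24.8 percentage points higher from compound 1 to compound 3 (beyond the scatter) and a number 12 percentage points higher from compound 2 to compound 3 (beyond the scatter). None of them, however, brings in acetylsulfamoyl, so the direction is uncertain. Since the group with the lowest number, methoxy in compound 1 at 4.2%, is the one carrying hydrogen-bond acceptors, a step downward of roughly a number 9 percentage points lower from compound 3 to compound 4 (within the scatter) is expected for compound 4, with a wide range. Compound 4 is estimated at 20%, between 4% and 60%.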

Compound 4, a percentage reported as activity, at one concentration (the size of the read-out at that concentration, not a potency): 0.35%
Compound 4: middle estimate off by 19.7 percentage points, on the high side; measured number outside the range, below it.
By their numbers in this assay, from the lowest: compounds 4 and 1 (each within the scatter of the next); then compound 2; then compound 3.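

In this assay, this aromatic carbon takes acetylsulfamoyl, a larger group than trifluoromethyl that brings a hydrogen-bond donor and hydrogen-bond acceptors, with a clear move toward a stronger effect: a number 28.7 percentage points lower from compound 3 to compound 4 (beyond the scatter) and a number 16.7 percentage points lower from compound 2 to compound 4 (beyond the scatter). Against methoxy the picture differs, with a number 3.9 percentage points lower from compound 1 to compound 4 (within the scatter), so two quite different groups cannot be told apart at the low end of this small series. No measurement at hand explains this result.

From the compounds shown here alone, it remains open whether the whole acetylsulfamoyl group matters or only part of it, which a plain sulfamoyl or a methylsulfonyl group on the same carbon would help to settle. Going by these compounds, how a carboxylic acid or an amine would behave there also stays unknown, and a reading at one concentration cannot separate compound 1 and compound 4 by potency.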